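Chloro to methyl swap: expectation for compound 3

A few compounds are considered here, and "the series" means these few. Any claim that something is new, unique, unknown or untested is made for them only; others in the source may bear on it.

Measured compounds:
compound 1, `Fc1ccc(C2CC(c3ccc(Cl)s3)=NN2c2nc(-c3ccc(Br)cc3)cs2)cc1`: 62.5 ug/mL
compound 2, `Cc1ccc(C2=NN(c3nc(-c4ccc(Cl)cc4)cs3)C(c3ccc(F)cc3)C2)s1`: > 500 ug/mL

Two compounds of the series have been run in a functional assay on A549 cells (Homo sapiens) for antiproliferative activity, read by XTT assay, with a stated time of 24 h; on this read-out lower numbers stand for stronger inhibition and higher numbers for weaker inhibition. Compound 1 gives 62.5 ug/mL. For compound 2 the assay reports only a limit, > 500 ug/mL, so compound 2 stands at the top end of the numbers shown, without a number of its own (the limit of > 500 ug/mL in this assay, at which 1 of the 2 values shown sits). Compound 1 and compound 2 differ in more than one place, and their two values show only that one sits at a number while the other sits at the limit.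

Compound 3, `Cc1ccc(-c2csc(N3N=C(c4ccc(C)s4)CC3c3ccc(F)cc3)n2)cc1`, is still to be measured. It differs from compound 2 by methyl in place of chloro on an aromatic carbon. Within the data shown here, no step between measured compounds is available, so nothing in the data sets the size of this move. The step from compound 2 to compound 3 is expected to stay within the scatter, an at least 1.1-fold lower number from compound 2 to compound 3 (0.04 log units; that floor lies within the scatter), with no direction to be read from what is known. Compound 3 is therefore estimated at 450 ug/mL, in the range 150 ug/mL to 700 ug/mL, and the assay may well again return only a limit.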

Compound 3, half-maximal inhibitory concentration: > 500 ug/mL
Compound 3: only a limit was reported; the forecaster's own chance of this, stated with the estimate: 60%; at least 1.1-fold (0.04 log units) between middle value and limit.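

Compound 2 and compound 3 each return only a limit in this assay, so the step between them, methyl in place of chloro on an aromatic carbon, cannot be read: the limit of > 500 ug/mL in this assay, at which 2 of the 3 values shown sit.

The compounds shown leave open both the size and the direction of the change from 4-chlorophenyl to 4-methylphenyl.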